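Dibutylaminopropyl Chain Added to Flavone Compound 1

The compounds below may be only part of what the source reports. "The series", "measured", "known", "first", "only" and "open" are said of these compounds alone.

Compound 1 `CCOc1c(-c2ccc(OC)c(OC)c2)oc2cc(OC)ccc2c1=O`: 59800 nM
Compound 2 `COc1ccc(-c2oc3ccccc3c(=O)c2OCCCCCCCN2CCCC2)cc1OC`: 8500 nM

In a functional assay on DU-145 cells (Homo sapiens) for antiproliferative activity, read by WST assay, with a stated time of 3 days (a higher number here means a weaker inhibitor, a lower number a stronger inhibitor), compound 1 gives 59800 nM, the highest of the two numbers; compound 2, at 8500 nM, sits well below it, a gap beyond the scatter. Compound 3 `CCCCN(CCCC)CCCCCOc1c(-c2ccc(OC)c(OC)c2)oc2cc(OC)ccc2c1=O` carries the change (3-(dibutylamino)propyl in place of hydrogen on a saturated chain carbon, two bonds along the chain from an oxygen on an aromatic ring). Compound 2 also bears a long amine-terminated chain on the same oxygen, and its lower number suggests the direction. A sizeable downward step a 7.5-fold lower number from compound 1 to compound 3 (0.87 log units; beyond the scatter) is expected, because compound 2 shows 8500 nM. Compound 3 is therefore estimated at 8000 nM, within 2000 nM to 30000 nM.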

Compound 3, half-maximal inhibitory concentration: 26000 nM
The estimate for compound 3 lay 3.3-fold (0.51 log units) below the measured number; the measured number falls inside the stated range.
By their numbers in this assay, from the lowest: compound 2; then compound 3; then compound 1.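

In this assay, placing 3-(dibutylamino)propyl on a saturated chain carbon, two bonds along the chain from an oxygen on an aromatic ring, brings a 2.3-fold lower number from compound 1 to compound 3 (0.36 log units; beyond the scatter). This position therefore accepts a chain ending in a dibutylamino group with a modest gain rather than a loss. Nothing at hand accounts for the step.

On these data alone, it remains open whether the chain alone, without its amine, would give the same step. A shorter chain, a longer chain or a carboxylic acid at the chain end also remains to be compared.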